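Taking the Chlorine Off Compound 1

A few compounds are considered here, and "the series" means these few. Any claim that something is new, unique, unknown or untested is made for them only; others in the source may bear on it.

Among the measured compounds shown here, compound 1 (`COc1ccc(-c2nc(C)c(C(=O)CSc3nc(N)c(C#N)c(-c4ccc(Cl)cc4)n3)s2)cc1`) holds the lower of the two numbers measured so far. In a functional assay on U-87MG ATCC cells for antiproliferative activity against U-87 MG (Homo sapiens), read by MTT assay, with a stated time of 48 h (a higher number here means a weaker inhibitor, a lower number a stronger inhibitor), compound 1 gives 4540 nM as its reading, while compound 2 (`COc1ccc(-c2nc(SCC(=O)c3sc(-c4ccccc4)nc3C)[nH]c(=O)c2C#N)cc1`) gives 48400 nM in the same test, a gap well beyond the usual scatter. These two compounds differ in more than one place, so their gap cannot be pinned on any single group.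

The next compound makes a cleaner comparison with compound 1. Compound 3 (`COc1ccc(-c2nc(C)c(C(=O)CSc3nc(N)c(C#N)c(-c4ccccc4)n3)s2)cc1`) carries hydrogen in place of chloro on an aromatic carbon, para to a large group (hydrogen in place of chloro on an aromatic carbon), so that 4-chlorophenyl becomes phenyl. Everything else stays the same, which makes this a single-place change. For the measured compounds named here, no measured pair shows what this change does, so any forecast is tentative. In this assay a modest step toward a higher number is expected, and the estimated step of a 2.2-fold higher number from compound 1 to compound 3 (0.34 log units; beyond the scatter) would mean a somewhat weaker inhibitor. The estimated value for compound 3 is 10000 nM with an expected range from 3500 nM to 30000 nM as the likely span.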

Compound 3, half-maximal inhibitory concentration: 8540 nM
For compound 3 the middle estimate is 1.2-fold (0.07 log units) above the measured one; the measured number falls inside the stated range.
By their numbers in this assay, from the lowest: compounds 1 and 3 (each within the scatter of the next); then compound 2.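

In this assay, putting hydrogen in place of chloro on an aromatic carbon, para to a large group, gives a 1.9-fold higher number from compound 1 to compound 3 (0.27 log units; within the scatter). This is the first comparison here in which only one place differs, and it shows that this test cannot tell 4-chlorophenyl and phenyl apart at this position, so the chlorine is not shown to matter for the reading. No available evidence bears on this result or says what the chlorine does at this place.

One swap at one position says little about the position as a whole: an amine, a carboxylic acid or a longer chain on the same aromatic carbon could behave quite differently, and the result gives no way to forecast them. The larger gap to compound 2 also remains unassigned, since compound 2 differs in more than one place from both compound 1 and compound 3, and a single-place comparison would be needed to tie that gap to any one group.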